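The compounds below may be only part of what the source reports. "The series", "measured", "known", "first", "only" and "open" are said of these compounds alone.

Measured in a functional assay on NCI-H460 cells (Homo sapiens) for cytotoxicity, read by MTT assay, with a stated time of 72 h; a higher number here means a weaker inhibitor, a lower number a stronger inhibitor:

compound 1, `COc1cc2c(Oc3ccc(NC(=O)c4nn(-c5ccccc5)c(=O)c5ccccc45)cc3F)ccnc2cc1OCCCN1CCN(C)CC1`: 450 nM
compound 2, `COc1cc2c(Oc3ccc(NC(=O)c4nn(-c5ccccc5F)c(=O)c5ccccc45)cc3F)ccnc2cc1OCCCN1CCN(C)CC1`: 230 nM
compound 3, `COc1cc2c(Oc3ccc(NC(=O)c4nn(-c5ccccc5Br)c(=O)c5ccccc45)cc3F)ccnc2cc1OCCCN1CCN(C)CC1`: 290 nM

Compound 3 stands second highest of the three numbers; compound 2 is nearest and compound 1 furthest, and both gaps sit within the scatter. All three share one core and differ only in the ring carried on the aromatic nitrogen.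

Compound 4, `COc1cc2c(Oc3ccc(NC(=O)c4nn(-c5ccc([N+](=O)[O-])cc5)c(=O)c5ccccc45)cc3F)ccnc2cc1OCCCN1CCN(C)CC1`, continues on that ring: 4-nitrophenyl in place of 2-bromophenyl on an aromatic nitrogen. The measured steps that bear on it are the three changes on the same ring: a 2.0-fold lower number from compound 1 to compound 2 (0.29 log units; within the scatter), a 1.6-fold lower number from compound 1 to compound 3 (0.19 log units; within the scatter) and a 1.3-fold higher number from compound 2 to compound 3 (0.10 log units; within the scatter). None of them leaves the scatter, so this ring has so far tolerated hydrogen, fluoro and bromo without a clear shift in this assay. Going by the values given here, no measured step covers a nitro group or a 4-substituted ring, so the new change is larger than any step seen here, but nothing measured points in either direction. The working expectation for compound 4 is therefore no step beyond the scatter, a 1.1-fold higher number from compound 3 to compound 4 (0.04 log units; within the scatter), with a wider range than usual to reflect the untested group. Compound 4 is estimated at 320 nM, between 110 nM and 950 nM.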

Compound 4, half-maximal inhibitory concentration: 980 nM
Compound 4: the middle estimate sits 3.1-fold (0.49 log units) below what was measured; the measured number lies above the stated range.
By their numbers in this assay, from the lowest: compounds 2, 3 and 1 (each within the scatter of the next); then compound 4.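

In this assay the ring on the aromatic nitrogen now shows a shift beyond the scatter: the series gives a 2.2-fold higher number from compound 1 to compound 4 (0.34 log units; beyond the scatter) and also a 4.3-fold higher number from compound 2 to compound 4 (0.63 log units; beyond the scatter) and a 3.4-fold higher number from compound 3 to compound 4 (0.53 log units; beyond the scatter) with each of these modest steps pointing towards a weaker inhibitor. The tolerance seen with hydrogen, fluoro and bromo therefore does not extend to 4-nitrophenyl, and this position is not indifferent to its substituent. No evidence at hand accounts for the shift.

The compounds shown leave open whether the shift follows the nitro group itself or its place on the ring, as 4-nitrophenyl is the only 4-substituted ring here. On these data alone, how an amine, a methoxy group or a carboxylic acid on this ring would behave also remains open.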